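This account rests on a few compounds, and the source may have more. Where it says the series, first, only, none or still open, it means among the compounds named here.

For the measured compounds named here, compound 2, `Cc1cc(Nc2cc(-c3ccccc3)[nH]n2)n2nc(SCc3ccc(Br)cc3)nc2n1`, gives 2720 nM in a functional assay on MCF7 cells (Homo sapiens) for inhibition, read by MTT assay, with a stated time of 72 h (on this read-out lower numbers stand for stronger inhibition and higher numbers for weaker inhibition), and on that read-out it shows the lowest of the three numbers so far. Its nearest neighbour is compound 3, `Cc1cc(Nc2ccn(Cc3ccc(F)cc3)n2)n2nc(SCc3ccc(Br)cc3)nc2n1`, which gives 4280 nM in this assay; the two values lie within the scatter of each other, so no order between them can be drawn. Compound 1, `Cc1cc(Nc2ccn(Cc3ccccc3)n2)n2nc(SCc3ccc(Br)cc3)nc2n1`, gives 15800 nM in this assay and stands furthest from compound 2, a gap beyond the scatter. Going by the values given here, the only step between measured compounds that differ in one place is a 3.7-fold lower number from compound 1 to compound 3 (0.57 log units; beyond the scatter).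

Compound 4, `Cc1cc(Nc2cc(-c3ccccc3)[nH]n2)n2nc(SCc3ccc(C(F)(F)F)cc3)nc2n1`, is taken from compound 2 by the change (trifluoromethyl in place of bromo on an aromatic carbon), at the place on an aromatic carbon of a six-membered aromatic ring of carbon only, para to a large group. Among the compounds with values here, no measured step touches that part of the molecule: the single step known, from compound 1 to compound 3, concerns the other benzyl group, so it gives no direct guide. With nothing to point either way, the step expected from compound 2 to compound 4 is a 1.1-fold higher number from compound 2 to compound 4 (0.04 log units; within the scatter), not beyond the scatter. Compound 4 is therefore estimated at 3000 nM in this assay, with a range from 1200 nM to 8000 nM.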

Compound 4, half-maximal inhibitory concentration: 4820 nM
The estimate for compound 4 lay 1.6-fold (0.21 log units) below the measured number; the measured number falls inside the stated range.
By their numbers in this assay, from the lowest: compounds 2, 3 and 4 (each within the scatter of the next); then compound 1.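

In this assay the first step measured at this part of the molecule is a 1.8-fold higher number from compound 2 to compound 4 (0.25 log units; within the scatter), so trifluoromethyl in place of bromo on an aromatic carbon, para to a large group, gives no order between the two compounds. At this place, a group of four heavy atoms thus stands in for one of a single heavy atom without a difference that this read-out can separate. The earlier step concerned the other benzyl group and could not show this about the 4-bromobenzyl part; no measurement at hand bears on why the result reads as it does.

From the compounds shown here alone, only bromo and trifluoromethyl are seen at this place, so it stays open whether an amine, a carboxylic acid or a methoxy group there would also give a number within the scatter of compound 2. Going by these compounds, it is also open whether trifluoromethyl in place of bromo would read the same on a compound that carries the other side of compound 3 rather than the side shared by compound 2 and compound 4.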